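A Bromine on the Benzyl Ring of Compound 2

This account rests on a few compounds, and the source may have more. Where it says the series, first, only, none or still open, it means among the compounds named here.

Two measured compounds set the scene. Compound 1 `CN(CCCNS(=O)(=O)c1cc(C(F)(F)F)cc(C(F)(F)F)c1)Cc1ccccc1` carries a methyl on its amine nitrogen, and compound 2 `O=S(=O)(NCCCNCc1ccccc1)c1cc(C(F)(F)F)cc(C(F)(F)F)c1` carries a hydrogen there instead. In a functional assay on BXPC-3 cells (Homo sapiens) for inhibition, read by MTT assay, with a stated time of 72 h (a higher number here means a weaker inhibitor of growth, a lower number a stronger inhibitor of growth), compound 1 gives 39000 nM, and compound 2 gives 13000 nM. Within the data shown here, the single step between them, a 3.0-fold lower number from compound 1 to compound 2 (0.48 log units; beyond the scatter), is the only measured change in this set. Among the two numbers, compound 2 stands lowest, with compound 1 as its nearest neighbour, beyond the scatter.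

Compound 3 `O=S(=O)(NCCCNCc1ccc(Br)cc1)c1cc(C(F)(F)F)cc(C(F)(F)F)c1` differs from compound 2 by bromo in place of hydrogen on an aromatic carbon. Among the measured compounds shown here, no measured step bears on this part of the molecule: the one step known concerns the amine nitrogen, not the benzyl ring, so its size says nothing direct about a bromine on that ring. The author therefore expects the step of a 1.3-fold lower number from compound 2 to compound 3 (0.11 log units; within the scatter) to stay within the usual scatter, with a modest chance of a lower number. For compound 3 the author estimates 10000 nM, with a range from 3000 nM to 30000 nM.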

Compound 3, concentration for 50% growth inhibition: 1500 nM
For compound 3 the middle estimate is 6.7-fold (0.82 log units) above the measured one, outside the stated range (below it).
By their numbers in this assay, from the lowest: compound 3; then compound 2; then compound 1.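

Among these compounds, the benzyl ring, which no earlier step had touched, turns out to be a sensitive place: in this assay a single bromo group on an aromatic carbon, para to a large group, gives an 8.7-fold lower number from compound 2 to compound 3 (0.94 log units; beyond the scatter) and makes compound 3 the lowest of the three. Set against the compound with the methyl on its amine nitrogen, the change to the (4-bromobenzyl)amino group gives a 26-fold lower number from compound 1 to compound 3 (1.41 log units; beyond the scatter), so the amine nitrogen and the benzyl ring are now both places where a change in structure moves the number, and in this set both moves run the same way. Nothing available here explains why this one added atom matters so much.

The compounds shown leave open whether the gain is particular to bromine or would also come with chlorine, fluorine, a methyl or a methoxy group on the same aromatic carbon, and whether bromine on another carbon of that ring would do the same. They also leave open whether a methyl on the amine nitrogen of compound 3 would cost as much as in the earlier pair, where the hydrogen gave a 3.0-fold lower number from compound 1 to compound 2 (0.48 log units; beyond the scatter) in the other direction of that change.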